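The source may report more compounds than this note shows. Statements on the series, on what has been measured and on what is new or still open speak of the compounds shown alone.

Two compounds of the series have numbers in a functional assay on cells (Cancer cell lines, Homo sapiens) for inhibition; a higher number here means a weaker inhibitor of growth, a lower number a stronger inhibitor of growth. Compound 1 `COc1ccc(-c2nc3sc(Cc4ccccc4)nn3c2SC#N)cc1` gives 61700 nM in this assay. Compound 2 `O=Cc1c(-c2ccc([N+](=O)[O-])cc2)nc2sc(Cc3ccccc3)nn12` gives 31600 nM in this assay, and the numbers of compound 2 and compound 1 lie within the scatter of each other, so neither stands apart. Compound 3 `O=[N+]([O-])c1ccc(-c2nc3sc(Cc4ccccc4)nn3c2Br)cc1` has not been measured; it differs from compound 2 by bromo in place of formyl on an aromatic carbon. For the measured compounds named here, no step of this kind has been measured. The expected step of a 1.3-fold lower number from compound 2 to compound 3 (0.10 log units; within the scatter) is small, with no direction claimed beyond the scatter. For compound 3 the estimate in this assay is 25000 nM, with a range from 8000 nM to 80000 nM.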

Compound 3, concentration for total growth inhibition: 83200 nM
Beside the measured number, compound 3's estimate is 3.3-fold (0.52 log units) below it; the whole stated range lies below it.
By their numbers in this assay, from the lowest: compounds 2, 1 and 3 (each within the scatter of the next, the first and the last beyond it).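

For the compounds shown here, at this position the substituent is not neutral in this assay: bromo in place of formyl gives a 2.6-fold higher number from compound 2 to compound 3 (0.42 log units; beyond the scatter) and is the only step that can be read at one place. The step is modest and rests on a single pair, so it gives a direction for these two groups only. Nothing at hand accounts for it. The compounds shown leave open how an amine, a carboxylic acid or a chloro group would read at this aromatic carbon. They also leave open whether the same step would hold with a group other than the 4-nitrophenyl-bearing arrangement shared by compound 2 and compound 3.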